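The source may hold more compounds than are shown below. What is called first, only, known or untested is meant among the compounds shown, and "the series" means these compounds.

Compound 1 `Cc1cc(Br)cc(C)c1Oc1cc(Nc2ccc(C#N)cc2)c(N)cc1N` and compound 2 `Cc1cc(C)c(Oc2cc(Nc3ccc(C#N)cc3)c(N)cc2N)c(C)c1` share one core; compound 3 `Cc1cc(Br)cc(C)c1Oc1ccc([N+](=O)[O-])c(Nc2ccc(C#N)cc2)c1` and compound 4 `Cc1cc(C)c(Oc2ccc([N+](=O)[O-])c(Nc3ccc(C#N)cc3)c2)c(C)c1` share another, and the difference between the two cores is not broken down here. In an ADME assay on H9 cells (Homo sapiens) for cytotoxicity, read by XTT assay, with a stated time of 6 days (a higher number here means that more compound is tolerated, a lower number that less compound is tolerated), compound 1 gives 38400 nM. In this assay compound 2 gives 50000 nM. The change methyl in place of bromo on an aromatic carbon yields a 1.3-fold higher number from compound 1 to compound 2 (0.11 log units; within the scatter). For compound 3 this assay reports only a limit, > 57000 nM, which is the limit of > 57000 nM in this assay, at which 1 of the 3 values shown sits. The change methyl in place of bromo on an aromatic carbon is the same change, carried onto the other core. Resting on the step of a 1.3-fold higher number from compound 1 to compound 2 (0.11 log units; within the scatter), a step of similar size is expected from compound 3 to compound 4 in this assay, namely a step that the limit leaves unreadable from compound 3 to compound 4. Compound 4 is therefore estimated at about 60000 nM, expected to fall between 35000 nM and 110000 nM, with a fair chance that this assay again returns only a limit.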

Compound 4, half-maximal cytotoxic concentration: > 67000 nM
Compound 4 ended at the assay's limit; the forecaster's own chance of this, stated with the estimate: 65%; middle value at least 1.1-fold (0.04 log units) away from the limit.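

For the compounds shown here, compound 3 and compound 4 each return only a limit in this assay, so no step between them can be read. Going by these compounds, whether methyl in place of bromo shifts the half-maximal cytotoxic concentration on their shared core remains open.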